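Swapping the aryl group: expected cytotoxicity of compound 4

The source may hold more compounds than are shown below. What is called first, only, known or untested is meant among the compounds shown, and "the series" means these compounds.

Of the compounds shown here, three have so far been measured in an ADME assay on Huh7.5.1 cells (Homo sapiens) for cytotoxicity, read by ATP content, with a stated time of 48 h; a higher number here means that more compound is tolerated, a lower number that less compound is tolerated. Compound 1 `Cc1oc(-c2ccc(F)cc2)nc1CN1CCC(C(=O)NCCCN2C[C@H](C)C[C@H](C)C2)CC1` gives 12800 nM, compound 2 `Cc1ccccc1-c1nc(CN2CCC(C(=O)N3CCN(C4CCN(C)CC4)CC3)CC2)c(C)o1` gives 19900 nM, and compound 3 `Cc1oc(-c2c(Cl)cccc2C(F)(F)F)nc1CN1CCC(C(=O)NCCCN2C[C@H](C)C[C@H](C)C2)CC1` gives 12000 nM. Compound 3 carries the lowest of the three numbers, but its gaps to compound 1 and to compound 2 both lie within the scatter, so the three values cannot be ranked against each other. Compound 4 `COc1cccc(OC)c1-c1nc(CN2CCC(C(=O)NCCCN3C[C@H](C)C[C@H](C)C3)CC2)c(C)o1` has not yet been measured in this assay. The change from compound 3 to compound 4 is 2,6-dimethoxyphenyl in place of 2-chloro-6-(trifluoromethyl)phenyl on an aromatic carbon. Among the compounds with values here, one measured step bears on this change, the earlier exchange of the group at the same position, which gave a 1.1-fold lower number from compound 1 to compound 3 (0.03 log units; within the scatter), that is, no movement beyond the scatter. On that ground no step beyond the scatter is expected in this assay, and the expected step is a 1.0-fold higher number from compound 3 to compound 4 (0.02 log units; within the scatter). Compound 4 is therefore estimated at 12500 nM, with a range from 6000 nM to 26000 nM.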

Compound 4, half-maximal cytotoxic concentration: 77100 nM
Beside the measured number, compound 4's estimate is 6.2-fold (0.79 log units) below it, outside the stated range (above it).
By their numbers in this assay, from the lowest: compounds 3, 1 and 2 (each within the scatter of the next); then compound 4.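

In this assay, this aryl position turns out not to be indifferent to the group it carries: the step is a 6.4-fold higher number from compound 3 to compound 4 (0.81 log units; beyond the scatter), and the comparison with the 4-fluorophenyl compound gives a 6.0-fold higher number from compound 1 to compound 4 (0.78 log units; beyond the scatter), whereas the earlier exchange at this position stayed within the scatter. Against 2-chloro-6-(trifluoromethyl)phenyl, the entering 2,6-dimethoxyphenyl has 2 hydrogen-bond acceptors where the leaving group has 0, though this count alone does not tie the rise to those atoms. No measurement at hand gives a reason for the rise.

The compounds shown leave open whether the rise needs both methoxy groups, which a phenyl carrying a single methoxy group or a 2,6-diethoxyphenyl group would help to settle. They also leave open whether 2,6-dimethoxyphenyl would give a similar step on the amide side of compound 2.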